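The source may hold more compounds than are shown below. What is called first, only, known or untested is meant among the compounds shown, and "the series" means these compounds.

Compound 3 `C[C@@H](CF)OC(=O)N1CCC(O[C@H]2CC[C@H](Oc3cnc(S(C)(=O)=O)cn3)CC2)CC1` gives 31.1 nM in a functional assay on isolated protein for agonist activity at Glucose-dependent insulinotropic receptor (Homo sapiens), read by HTRF and cAMP accumulation; on this read-out higher numbers stand for an effect only at larger amounts of compound and lower numbers for an effect already at smaller amounts. Compound 1 `CC(C)(C)OC(=O)N1CCC(O[C@H]2CC[C@H](Oc3ccc(S(C)(=O)=O)c(F)c3)CC2)CC1` gives 52 nM. Compound 2 `CC(C)(C)OC(=O)N1CCC(O[C@H]2CC[C@H](Oc3ccc(S(C)(=O)=O)nn3)CC2)CC1` gives 651 nM.

Among the three measured compounds, compound 3 has the lowest number in this assay, but its nearest neighbour, compound 1, stands within the scatter of it, so the two cannot be ranked against each other; compound 2 stands well beyond the scatter and is the only one of the three that is clearly separated. Compound 4 `CS(=O)(=O)c1cnc(O[C@H]2CC[C@H](OC3CCN(CC4(C(F)(F)F)CCCC4)CC3)CC2)cn1` has not yet been measured. It differs from compound 3 in one place: a group of 10 heavy atoms (7 carbon, 3 fluorine; one five-membered non-aromatic ring of carbon only) in place of a group of 7 heavy atoms (4 carbon, 2 oxygen, 1 fluorine; no ring), on an amine nitrogen in a ring. The group that leaves is a carbamate; the group that enters is a carbon chain on the same amine nitrogen in a ring. No step between measured compounds covers this kind of exchange, so there is no precedent among the shown compounds for its size or direction. For compound 4 the number in this assay is therefore expected to stay close to that of compound 3, with the step of a 1.3-fold higher number from compound 3 to compound 4 (0.11 log units; within the scatter) most likely within the scatter, and compound 4 is estimated at 40 nM, in a range from 10 nM to 160 nM.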

Compound 4, half-maximal effective concentration: 48.8 nM
The estimate for compound 4 lay 1.2-fold (0.09 log units) below the measured number, within the range that was stated.
By their numbers in this assay, from the lowest: compounds 3, 4 and 1 (each within the scatter of the next); then compound 2.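

Going by these compounds alone, all the earlier compounds carry a carbamate on this amine nitrogen in a ring, so they could not show whether that group can be exchanged. In this assay, replacing it with a carbon chain bearing a five-membered non-aromatic ring of carbon only gives a 1.6-fold higher number from compound 3 to compound 4 (0.20 log units; within the scatter), so for this pair the carbamate is not required for activity at this level, and its oxygen atoms can be lost without a change beyond the scatter. Nothing shown accounts for this outcome. As far as these compounds go, it remains open whether a urea or an amide on the same nitrogen would behave alike, and whether a methyl in place of the trifluoromethyl would alter the number. The compounds shown also leave open whether the same exchange would hold on the cores of compound 1 and compound 2.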